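Cytotoxicity step from an amine side chain to a diol

The source may report more compounds than this note shows. Statements on the series, on what has been measured and on what is new or still open speak of the compounds shown alone.

Compound 1, `CN(C)CCNc1nc(F)c(-c2nn(Cc3ccc(C#N)cc3)c(=O)c3ccccc23)cc1Cl`: 9760 nM
Compound 2, `COc1cc(-c2ccc(F)nc2F)nn(Cc2ccc(Cl)cc2)c1=O`: 92200 nM
Compound 3, `O=c1c2ccccc2c(-c2ccc(F)nc2F)nn1Cc1ccc(Cl)cc1`: 36700 nM

Of the compounds shown here, three have been measured in an ADME assay on HepG2 2.2.15 cells (Homo sapiens) for cytotoxicity, read by MTT assay, with a stated time of 8 days; a lower number here means that less compound is tolerated, a higher number that more compound is tolerated. Compound 1 gives 9760 nM, the lowest of the three numbers; compound 3 and compound 2 both lie above it by more than the scatter, so compound 1 is the least tolerated of the set on these numbers.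

The unmeasured compound 4, `N#Cc1ccc(Cn2nc(-c3cc(Cl)c(NC[C@@H](O)CO)nc3F)c3ccccc3c2=O)cc1`, differs from compound 1 in a single place: 1,2-dihydroxyethyl in place of (dimethylamino)methyl on a saturated chain carbon bound to a nitrogen on an aromatic ring. Among the measured compounds shown here, no pair of measured compounds shows this particular change, so there is no step to lean on. In this assay the expected outcome for compound 4 is a modest rise in the half-maximal cytotoxic concentration, of a size that may just exceed the scatter, in the direction of more compound being tolerated. On that basis compound 4 is estimated at 22000 nM, with a range from 8000 nM to 60000 nM, corresponding to an expected step of a 2.3-fold higher number from compound 1 to compound 4 (0.35 log units; beyond the scatter).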

Compound 4, half-maximal cytotoxic concentration: > 100000 nM
Compound 4 was reported as a limit (the forecaster's own chance of this, stated with the estimate: 10%); middle value at least 4.5-fold (0.65 log units) away from the limit.
By their numbers in this assay, from the lowest: compound 1; then compound 3; then compound 2. At a limit, above all of these: compound 4.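

In this assay, placing 1,2-dihydroxyethyl where (dimethylamino)methyl stood, on a saturated chain carbon bound to a nitrogen on an aromatic ring, gives an at least 10-fold higher number from compound 1 to compound 4 (1.01 log units; beyond the scatter). Compound 4 stands at > 100000 nM, which is a limit of the assay and not a number. The step is thus a minimum, and it shows what the earlier compounds, with no single-place pair among them, could not: changing this chain alone moves the tolerated concentration well beyond the scatter, on this reading: the limit of > 100000 nM in this assay, at which 1 of the 4 values shown sits.

This one pair cannot separate losing the dimethylamino group from gaining the diol. Still open, going by these compounds, is how a chain ending in a single hydroxyl, a primary amine or a carboxylic acid would read, and whether the mirror-image diol would match compound 4.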